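Tail variation at the carbonyl and maximal response

This account rests on a few compounds, and the source may have more. Where it says the series, first, only, none or still open, it means among the compounds named here.

The three measured compounds share one core and differ only in the group on the carbonyl carbon attached to the amide-type nitrogen in a ring. In a functional assay on isolated protein for inhibition of Glucose-dependent insulinotropic receptor (Rattus norvegicus), read by HTRF and cAMP accumulation (on this read-out higher numbers stand for larger maximal responses and lower numbers for smaller maximal responses), compound 1 `Cc1nc(S(C)(=O)=O)ccc1Oc1ncnc(OC2CCN(C(=O)OC(C)(C)C#N)CC2)c1F` gives 97%, compound 2 `Cc1nc(S(C)(=O)=O)ccc1Oc1ncnc(OC2CCN(C(=O)O[C@H](C)CF)CC2)c1F` gives 79%, and compound 3 `Cc1nc(S(C)(=O)=O)ccc1Oc1ncnc(OC2CCN(C(=O)OC3COC3)CC2)c1F` gives 66%. Compound 3 thus stands lowest of the three: the step of a number 13 percentage points lower from compound 2 to compound 3 (beyond the scatter) is modest, the step of a number 31 percentage points lower from compound 1 to compound 3 (beyond the scatter) is large, and the step of a number 18 percentage points lower from compound 1 to compound 2 (beyond the scatter) lies between them.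

Compound 4 `Cc1nc(S(C)(=O)=O)ccc1Oc1ncnc(OC2CCN(C(=O)SC3CCC3)CC2)c1F` changes the same position: cyclobutylsulfanyl in place of (oxetan-3-yl)oxy on a carbonyl carbon. Every measured step in this assay bears on it, since each replaces the group on that carbonyl, but none of them exchanges the oxygen for sulfur or removes all ring hetero atoms, so the direction is not fixed by the data. The measured steps show that this position moves the maximal response by modest to large amounts. Since compound 3 is the lowest point, an upward step is expected as the more likely outcome, but with a wide range. For compound 4 the expected value is 78%, between 55% and 100%, an estimated step of a number 12 percentage points higher from compound 3 to compound 4 (beyond the scatter).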

Compound 4, largest response reached (reported as efficacy), in percent of the reference or control that the assay uses: 81%
The estimate for compound 4 lay 3 percentage points below the measured number; the measured number falls inside the stated range.
By their numbers in this assay, from the lowest: compound 3; then compounds 2 and 4 (each within the scatter of the next); then compound 1.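

In this assay, the position accepts a linking sulfur with a carbon-only four-membered ring and does not stay at the level of compound 3 (a number 15 percentage points higher from compound 3 to compound 4 (beyond the scatter)), so a low maximal response does not follow from the four-membered ring as such. The cyclobutylsulfanyl group of compound 4 and the open-chain group of compound 2 cannot be told apart on this read-out (a number 2 percentage points higher from compound 2 to compound 4 (within the scatter)), although they share neither ring nor linking atom, while the 1-cyano-1-methylethoxy group of compound 1 remains clear of compound 4 (a number 16 percentage points lower from compound 1 to compound 4 (beyond the scatter)). Nothing available here accounts for these differences.

The exchange from compound 3 to compound 4 alters the linking atom and the ring atoms together, so the share of each in the step stays unresolved; cyclobutyloxy on the same carbonyl carbon would separate the two. Also open, as far as these compounds go, is how a nitrogen link, as in a cyclobutylamino group, or a longer carbon chain on the sulfur would read against compound 1 and compound 4.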